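This account rests on a few compounds, and the source may have more. Where it says the series, first, only, none or still open, it means among the compounds named here.

Measured so far:
compound 1, `CC(C)(C)OC(=O)NCCNCC(=O)Nc1c[nH]c(=O)[nH]c1=O` — 50000 nM
compound 2, `Cc1cc(=O)[nH]c(=O)n1COC(CO)CO` — > 100000 nM

In a functional assay on SW-620 cells (Homo sapiens) for inhibition, read by MTT assay, with a stated time of 72 h (on this read-out lower numbers stand for stronger inhibition and higher numbers for weaker inhibition), compound 1 gives 50000 nM, a weak but numbered result. Compound 2 gives no number in this assay: its entry, > 100000 nM, is a limit of the assay, and compound 2 therefore stands at the limit of > 100000 nM in this assay, at which 1 of the 2 values shown sits. For the measured compounds named here, of the two measured compounds compound 2 is thus the one whose inhibition could not be resolved, while compound 1 sits at a measurable, if weak, concentration; no single-point step connects these two structures, so no comparison beyond their two values is drawn.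

Compound 3, `Cc1c(I)c(=O)[nH]c(=O)n1COC(CO)CO`, has not yet been measured. It differs from compound 2 by iodo in place of hydrogen on an aromatic carbon. Since compound 2 stands at a limit, any change in this assay can only be read as either a move into the measurable range or a second limit. Going by the values given here, no measured step exists to anchor the size of this change, so only a guarded expectation is offered: the step from compound 2 to compound 3 is expected to be modest, toward stronger inhibition at best, as an at least 1.4-fold lower number from compound 2 to compound 3 (0.15 log units; that floor lies within the scatter). Compound 3 is accordingly expected near 70000 nM, within a range of 20000 nM to 150000 nM, with a real chance that it too returns only a limit.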

Compound 3, half-maximal inhibitory concentration: > 100000 nM
Compound 3: a limit, no number; the forecaster's own chance of this, stated with the estimate: 50%; middle value at least 1.4-fold (0.15 log units) from the limit.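

In this assay compound 3 gives > 100000 nM, a limit of the assay and not a number. Compound 2 also gives only a limit, so no step can be read between compound 2 and compound 3: the limit of > 100000 nM in this assay, at which 2 of the 3 values shown sit.

The compounds shown leave open whether iodo in place of hydrogen on an aromatic carbon changes inhibition at all.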